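This account rests on a few compounds, and the source may have more. Where it says the series, first, only, none or still open, it means among the compounds named here.

Within the data shown here, in a functional assay on PC-3 cells (Homo sapiens) for antiproliferative activity, read by MTT assay, with a stated time of 48 h (a higher number here means a weaker inhibitor, a lower number a stronger inhibitor), compound 2 `CCOC(=O)CN(C)C(=O)c1ccc(C(CC)(CC)c2ccc(OCCC(O)(CC)CC)c(C)c2)n1CC` gives 7140 nM, the higher of the two numbers so far and therefore the weaker result. Among the measured compounds shown here, the only other measured compound, compound 1 `CCn1c(C(=O)NCCN)ccc1C(CC)(CC)c1ccc(OCCC(O)(CC)CC)c(C)c1`, gives 2420 nM. Compound 3 `CCOC(=O)C(CC(=O)OC)NC(=O)c1ccc(C(CC)(CC)c2ccc(OCCC(O)(CC)CC)c(C)c2)n1CC` keeps the shared core of compound 2 and differs only in the group on a carbonyl carbon: a group of 12 heavy atoms (7 carbon, 1 nitrogen, 4 oxygen; no ring) in place of a group of 8 heavy atoms (5 carbon, 1 nitrogen, 2 oxygen; no ring), on a carbonyl carbon. One measured step changes that same place: a 3.0-fold higher number from compound 1 to compound 2 (0.47 log units; beyond the scatter). For the measured compounds named here, it is a modest step, and it is the only guide available, since no measured compound carries the new group. No clear direction follows from it, so no shift beyond the scatter is expected in this assay. The expected change is a 1.1-fold lower number from compound 2 to compound 3 (0.04 log units; within the scatter). Compound 3 is estimated at 6500 nM, with an expected range of 2500 nM to 17000 nM.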

Compound 3, half-maximal inhibitory concentration: 5840 nM
For compound 3 the middle estimate is 1.1-fold (0.05 log units) above the measured one, within the range that was stated.
By their numbers in this assay, from the lowest: compound 1; then compounds 3 and 2 (each within the scatter of the next).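

In this assay, the group on the carbonyl carbon goes from 8 to 12 heavy atoms and from 0 to 1 hydrogen-bond donor, yet the step is a 1.2-fold lower number from compound 2 to compound 3 (0.09 log units; within the scatter), so at this position that large change in the group brings no readable shift. The second step, a 2.4-fold higher number from compound 1 to compound 3 (0.38 log units; beyond the scatter), lies beyond the scatter and points the same way as the step to compound 2. Among these three compounds, both ester-bearing groups give higher numbers than the (2-aminoethyl)amino group of compound 1, and none goes against this. No data at hand explain this difference.

The compounds shown leave open whether the amine or the absence of an ester matters here. A carboxylic acid in place of the ester, or a longer chain carrying the amine, could help separate the two.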